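Replacing dimethylamino with vinyl: compound 3 in prospect

The compounds below may be only part of what the source reports. "The series", "measured", "known", "first", "only" and "open" are said of these compounds alone.

Compound 1 `COc1cc(-c2ccnc3cc(-c4cccc(C#N)c4)nn23)cc(OC)c1OC` gives > 10000 nM as a limit of the assay
Compound 2 `COc1cc(-c2ccnc3cc(-c4ccc(N(C)C)cc4)nn23)cc(OC)c1OC` gives 2050 nM as a measured number

Going by the values given here, in a functional assay on HCT-116 cells (Homo sapiens) for inhibition, read by CCK-8 assay, with a stated time of 48 h (a higher number here means a weaker inhibitor, a lower number a stronger inhibitor), compound 2 holds the only number, and the sole other result is a limit. Compound 3 `C=Cc1ccc(-c2cc3nccc(-c4cc(OC)c(OC)c(OC)c4)n3n2)cc1` has vinyl in place of dimethylamino on an aromatic carbon and otherwise matches compound 2. Among the compounds with values here, the one measured step bearing on this is an at least 4.8-fold lower number from compound 1 to compound 2 (0.68 log units; beyond the scatter) and its size is known only as a bound. It gained with the arrival of dimethylamino, which compound 3 gives up, so a modest move to a higher number is expected. The estimate is a 1.5-fold higher number from compound 2 to compound 3 (0.17 log units; within the scatter) for this change. Compound 3 is expected in this assay at 3000 nM with an estimated range of 800 nM to 10000 nM around it.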

Compound 3, half-maximal inhibitory concentration: 1060 nM
Compound 3: the middle estimate sits 2.8-fold (0.45 log units) above what was measured, and the stated range covers the measured number.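

In this assay, the change from dimethylamino to vinyl gives a 1.9-fold lower number from compound 2 to compound 3 (0.29 log units; within the scatter), so this aromatic carbon tolerates a group without nitrogen or a hydrogen-bond acceptor, and the number reached with compound 2 does not depend on dimethylamino. With 4-vinylphenyl in place of 3-cyanophenyl, the result is an at least 9.4-fold lower number from compound 1 to compound 3 (0.97 log units; beyond the scatter). The size of that step is known only as a bound, because compound 1 stands at a limit: the limit of > 10000 nM in this assay, at which 1 of the 3 values shown sits.

From the compounds shown here alone, whether a primary amine, a carboxylic acid or a longer alkyl chain here would move the number beyond the scatter remains open. So does whether the 4-vinylphenyl gain comes from losing the nitrile or from where the group sits.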